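The source may report more compounds than this note shows. Statements on the series, on what has been measured and on what is new or still open speak of the compounds shown alone.

The series shares the core of compound 1 `Cn1c(=O)c(=O)n(C2CCCC2)c2nc(N/N=C/c3cc(C(F)(F)F)c(O)c(C(F)(F)F)c3)ncc21` and varies the group on a carbon with a double bond to nitrogen. In a functional assay on PC-3 cells (Homo sapiens) for antiproliferative activity, read by MTT assay (a lower number here means a stronger inhibitor, a higher number a weaker inhibitor), compound 1 gives 17700 nM. Compound 2 `Cn1c(=O)c(=O)n(C2CCCC2)c2nc(N/N=C/c3cccc(Cl)c3Cl)ncc21` gives 17200 nM in this assay, and compound 3 `Cn1c(=O)c(=O)n(C2CCCC2)c2nc(N/N=C/c3ccco3)ncc21` gives 72200 nM. Compound 3 therefore stands highest of the three numbers in this assay: the step of a 4.2-fold higher number from compound 2 to compound 3 (0.62 log units; beyond the scatter) lies beyond the scatter, and the gap to compound 1 is of the same order.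

Compound 4 `Cn1c(=O)c(=O)n(C2CCCC2)c2nc(N/N=C/c3ccccc3F)ncc21` differs from compound 3 in one place: 2-fluorophenyl in place of furan-2-yl on a carbon with a double bond to nitrogen. Among the compounds with values here, the only measured step that bears on this change is a 4.2-fold higher number from compound 2 to compound 3 (0.62 log units; beyond the scatter), in which 2,3-dichlorophenyl gave way to furan-2-yl and the number rose. Within the data shown here, the present step brings back a six-membered aromatic ring of carbon only, now bearing one fluorine rather than two chlorines, so a step back down in this assay of roughly similar size is expected, with added uncertainty since no measured compound carries a fluorine on this ring. Compound 4 is expected to come in near 20000 nM, within 8000 nM to 50000 nM, which corresponds to an expected step of a 3.6-fold lower number from compound 3 to compound 4 (0.56 log units; beyond the scatter).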

Compound 4, half-maximal inhibitory concentration: 27600 nM
The estimate for compound 4 lay 1.4-fold (0.14 log units) below the measured number; measured number inside the range.
By their numbers in this assay, from the lowest: compounds 2, 1 and 4 (each within the scatter of the next); then compound 3.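

In this assay, a six-membered aromatic ring of carbon only in place of furan-2-yl gives a 2.6-fold lower number from compound 3 to compound 4 (0.42 log units; beyond the scatter), so the rise in a 4.2-fold higher number from compound 2 to compound 3 (0.62 log units; beyond the scatter) is not specific to the loss of the 2,3-dichlorophenyl group: a ring with a single fluorine also lies lower than furan-2-yl. Exchanging 2,3-dichlorophenyl for 2-fluorophenyl gives a 1.6-fold higher number from compound 2 to compound 4 (0.21 log units; within the scatter), so the two substituted phenyl groups are not separated here, and the chlorines are not required for the lower number. Nothing measured on these compounds explains the difference between furan-2-yl and the phenyl groups.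

Open, on these data alone, is whether ring size or the ring oxygen separates furan-2-yl from the phenyl groups; thiophen-2-yl and pyridin-2-yl would distinguish these. Also open, as far as these compounds go, is how an amine or a carboxylic acid on the phenyl ring would read.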